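Chloro to bromo on the anilino ring: expectation

The source may hold more compounds than are shown below. What is called first, only, known or untested is meant among the compounds shown, and "the series" means these compounds.

Compound 1 `Fc1cccc(-c2nc(Nc3ccccc3)c3cc(F)ccc3n2)c1` carries an unsubstituted anilino group on the shared core. In a functional assay on MCF7 cells (Homo sapiens) for cytotoxicity, read by MTT assay, with a stated time of 48 h (a lower number here means a stronger inhibitor, a higher number a weaker inhibitor), compound 1 gives 49700 nM. Compound 2 `Fc1cccc(-c2nc(Nc3ccccc3F)c3cc(F)ccc3n2)c1` adds a fluoro to that ring. In this assay compound 2 reaches only the limit of the measurement, > 50000 nM. Compound 3 `Fc1cccc(-c2nc(Nc3ccccc3Cl)c3cc(F)ccc3n2)c1` carries chloro in the same place. In this assay compound 3 likewise returns a limit, > 50000 nM. The step of a number no lower from compound 1 to compound 2 (the limit leaves the size open) and the step of a number no lower from compound 1 to compound 3 (the limit leaves the size open) are both cut off by the limit, and the step that the two limits leave unreadable from compound 2 to compound 3 is unreadable for the same reason. Two of the three values sit at the limit of > 50000 nM in this assay, at which 2 of the 3 values shown sit, so compound 3 stands at that limit with no readable number of its own.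

Compound 4 `Fc1cccc(-c2nc(Nc3ccccc3Br)c3cc(F)ccc3n2)c1` differs from compound 3 by bromo in place of chloro on an aromatic carbon. Among the compounds with values here, the steps that bear on it, a number no lower from compound 1 to compound 3 (the limit leaves the size open) and a step that the two limits leave unreadable from compound 2 to compound 3, give no size. Within the data shown here, nothing among the measured compounds points to a readable value emerging with bromo, so the expectation for compound 4 in this assay is a step that the limit leaves unreadable from compound 3 to compound 4 that stays at or around the limit. Compound 4 is estimated at 60000 nM, between 20000 nM and 200000 nM, most likely reported only as a limit.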

Compound 4, half-maximal inhibitory concentration: > 50000 nM
Compound 4: no number, only a limit; the forecaster's own chance of this, stated with the estimate: 85%; the middle value does not contradict the limit.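

With bromo, the same aromatic carbon, ortho to a large group, now carries three different halogens, and none of compound 2, compound 3 or compound 4 gives a readable number in this assay. The steps among these three compounds cannot be read, so no order among fluoro, chloro and bromo can be drawn, and the step of a number no lower from compound 1 to compound 4 (the limit leaves the size open) gives a direction without a size. Bromo extends the run of results at the limit to a third halogen at this place: the limit of > 50000 nM in this assay, at which 3 of the 4 values shown sit.

Within the data shown here, compound 1, with hydrogen at this place, gives 49700 nM, the only number in this set, so no substituent effect of any size can yet be stated in this assay. From the compounds shown here alone, it remains open whether a group other than a halogen, such as a methoxy, an amine or a carboxylic acid, would return a readable number at this place, and whether any change elsewhere on the shared core would do so.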